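Butyl in place of 1-phenylethyl on the amine nitrogen

The compounds below may be only part of what the source reports. "The series", "measured", "known", "first", "only" and "open" are said of these compounds alone.

Measured so far:
compound 1 `COc1cc2c(cc1C(C)NCCCc1ccccc1)C=CC(C)(C)O2`, 11 nM
compound 2 `COc1cc2c(cc1C(C)N[C@H](C)c1ccccc1)C=CC(C)(C)O2`, 232 nM

In an assay on cell membranes for displacement of a labelled ligand from Sigma non-opioid intracellular receptor 1 (Cavia porcellus), read by scintillation counting (a higher number here means a weaker inhibitor, a lower number a stronger inhibitor), compound 1 gives 11 nM, and compound 2 gives 232 nM, the highest of the two numbers, a gap to compound 1 that lies beyond the scatter. Compound 3 `CCCCNC(C)c1cc2c(cc1OC)OC(C)(C)C=C2` carries the change (butyl in place of 1-phenylethyl on an amine nitrogen). Within the data shown here, no measured pair shows this step, so only an expectation is possible. Compound 3 is expected to show a drop, a 5.8-fold lower number from compound 2 to compound 3 (0.76 log units; beyond the scatter), as the flexible chain of compound 1 went with 11 nM. Compound 3 is estimated at 40 nM, within 8 nM to 200 nM.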

Compound 3, inhibition constant: 22 nM
Compound 3: the middle estimate sits 1.8-fold (0.26 log units) above what was measured; low and high end bracket the measured number.
By their numbers in this assay, from the lowest: compounds 1 and 3 (each within the scatter of the next); then compound 2.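

In this assay, butyl in place of 1-phenylethyl on the amine nitrogen gives an 11-fold lower number from compound 2 to compound 3 (1.02 log units; beyond the scatter), so at this position a substituent with no ring can carry a much lower number than 1-phenylethyl. Methyl in place of phenyl on a saturated chain carbon, three bonds along the chain from an amine nitrogen, gives a 2.0-fold higher number from compound 1 to compound 3 (0.30 log units; within the scatter), so the phenyl of compound 1 is not needed to hold a value in this range. No measurement here accounts for these steps. The compounds shown leave open how a shorter chain such as ethyl or a longer chain such as hexyl would compare with butyl. They also leave open whether benzyl, with its ring closer to the nitrogen, would behave like 1-phenylethyl.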